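Halogen exchange in the series: chloro to fluoro

The source may hold more compounds than are shown below. What is called first, only, known or untested is meant among the compounds shown, and "the series" means these compounds.

In a functional assay on T98G cells (Homo sapiens) for inhibition, read by MTT assay, with a stated time of 72 h (on this read-out higher numbers stand for weaker inhibition and lower numbers for stronger inhibition), compound 1 (`CC1(C)CC(NC(=S)Nc2cccc([N+](=O)[O-])c2)c2cc(Br)ccc2O1`) gives 4000 nM and compound 2 (`CC1(C)CC(NC(=S)Nc2cccc([N+](=O)[O-])c2)c2cc(Cl)ccc2O1`) gives 4000 nM as its value. Compound 2 therefore stands level with compound 1. Within the data shown here, the only measured step, no change at the digits printed from compound 1 to compound 2 (within the scatter), is chloro in place of bromo on an aromatic carbon. Compound 3 (`CC1(C)CC(NC(=S)Nc2cccc([N+](=O)[O-])c2)c2cc(F)ccc2O1`) differs by fluoro in place of chloro on an aromatic carbon. Among the measured compounds shown here, with that one halogen step as the sole guide, the expected change, a 1.1-fold higher number from compound 2 to compound 3 (0.05 log units; within the scatter), stays within the scatter. In this assay compound 3 is estimated at 4500 nM, with an expected range of 2000 nM to 10000 nM.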

Compound 3, half-maximal inhibitory concentration: 9000 nM
Estimate against measurement, compound 3: 2.0-fold (0.30 log units) below; the measured number falls inside the stated range.
By their numbers in this assay, from the lowest: compounds 1 and 2 (each within the scatter of the next); then compound 3.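

In this assay the halogen on this aromatic carbon turns out not to be freely exchangeable: fluoro in place of chloro gives a step beyond the scatter (a 2.3-fold higher number from compound 2 to compound 3 (0.35 log units; beyond the scatter)), and fluoro in place of bromo gives another (a 2.3-fold higher number from compound 1 to compound 3 (0.35 log units; beyond the scatter)). Bromo and chloro alone had shown no such sensitivity, so among these three halogens only fluoro separates. No measurement shown accounts for this difference.

Still open, as far as these compounds go, is whether a methoxy group or a nitrile at this place would stand with fluoro or with chloro and bromo.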